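From Methoxy to Dimethylamino on the Shared Core

The compounds below may be only part of what the source reports. "The series", "measured", "known", "first", "only" and "open" are said of these compounds alone.

In a functional assay on KB cells (Homo sapiens) for inhibition, read by sulforhodamine B assay (a lower number here means a stronger inhibitor of growth, a higher number a weaker inhibitor of growth), compound 1 (`FC(F)(F)Oc1ccc(-c2ccc(-c3ccc(-c4nc5ccccc5[nH]4)cc3)cc2)cc1`) gives 39100 nM, compound 2 (`Oc1ccc(-c2ccc(-c3ccc(-c4nc5ccccc5[nH]4)cc3)cc2)cc1`) gives 41000 nM, and compound 3 (`COc1ccc(-c2ccc(-c3ccc(-c4nc5ccccc5[nH]4)cc3)cc2)cc1`) gives 47200 nM. Compound 3 therefore stands level with both others, within the scatter. Compound 4 (`CN(C)c1ccc(-c2ccc(-c3ccc(-c4nc5ccccc5[nH]4)cc3)cc2)cc1`) carries dimethylamino in place of methoxy on an aromatic carbon, para to a large group: dimethylamino in place of methoxy on an aromatic carbon. The measured steps that bear on this change alter only the group on the oxygen: a 1.0-fold higher number from compound 1 to compound 2 (0.02 log units; within the scatter), a 1.2-fold higher number from compound 1 to compound 3 (0.08 log units; within the scatter) and a 1.2-fold higher number from compound 2 to compound 3 (0.06 log units; within the scatter). All three lie within the scatter, though none introduces dimethylamino. The estimated 1.2-fold lower number from compound 3 to compound 4 (0.09 log units; within the scatter) is thus expected to stay within the scatter. For compound 4 the expected value is 38000 nM, with an estimated range of 17000 nM to 80000 nM.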

Compound 4, concentration for 50% growth inhibition: 39300 nM
Estimate against measurement, compound 4: 1.0-fold (0.01 log units) below; measured number inside the range.
By their numbers in this assay, from the lowest: compounds 1, 4, 2 and 3 (each within the scatter of the next).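

In this assay this position accepts dimethylamino, which brings nitrogen where the earlier groups had oxygen, and the compounds stay level: the steps are a 1.2-fold lower number from compound 3 to compound 4 (0.08 log units; within the scatter) and a 1.0-fold lower number from compound 2 to compound 4 (0.02 log units; within the scatter) and a 1.0-fold higher number from compound 1 to compound 4 (0.00 log units; within the scatter) and all three lie within the scatter. The flat picture seen among groups on the oxygen thus extends, across these four compounds, to a group joined through nitrogen. No supporting data bear on this result.

The compounds shown leave open whether a carboxylic acid, a primary amine or a longer chain at this position would move the number beyond the scatter.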